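Ester chains, from compound 3 to compound 4

The source may hold more compounds than are shown below. What is called first, only, known or untested is meant among the compounds shown, and "the series" means these compounds.

In an ADME assay on Vero cells (Chlorocebus sabaeus) for cytotoxicity, read by MTT assay (on this read-out lower numbers stand for stronger inhibition and higher numbers for weaker inhibition), compound 3 `CCCCCCC(C)C(=O)OCC(C)(C)CC1=C(O)C(=O)c2ccccc2C1=O` gives 450 nM, the lowest of the three numbers, against compound 1 `CCC(CC)C(=O)OCC(C)(C)CC1=C(O)C(=O)c2ccccc2C1=O` at 104000 nM and compound 2 `CCCCCC(=O)OCC(C)(C)CC1=C(O)C(=O)c2ccccc2C1=O` at 169000 nM. Compound 4 `CCCCCCCCCC(=O)OCC(C)(C)CC1=C(O)C(=O)c2ccccc2C1=O` carries nonyl in place of 1-methylheptyl on a carbonyl carbon. For the measured compounds named here, three measured steps bear on this change. The step of a 1.6-fold higher number from compound 1 to compound 2 (0.21 log units; within the scatter) swaps pentan-3-yl for pentyl and stays within the scatter. The steps of a 230-fold lower number from compound 1 to compound 3 (2.36 log units; beyond the scatter) and a 380-fold lower number from compound 2 to compound 3 (2.57 log units; beyond the scatter) are both large and both end at 1-methylheptyl. On the evidence of a 1.6-fold higher number from compound 1 to compound 2 (0.21 log units; within the scatter), the expected change in this assay is none beyond the scatter, namely a 1.6-fold higher number from compound 3 to compound 4 (0.19 log units; within the scatter). Going by the values given here, no measured compound carries nonyl, so the range is kept wide towards higher numbers. For compound 4 the estimated value is 700 nM, with an expected range of 120 nM to 8000 nM.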

Compound 4, half-maximal inhibitory concentration: 203000 nM
Estimate against measurement, compound 4: 290-fold (2.46 log units) below, outside the stated range (above it).
By their numbers in this assay, from the lowest: compound 3; then compounds 1, 2 and 4 (each within the scatter of the next).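

In this assay the step of a 450-fold higher number from compound 3 to compound 4 (2.65 log units; beyond the scatter) is large, so on this carbonyl carbon nonyl and 1-methylheptyl are not interchangeable. The steps of a 1.2-fold higher number from compound 2 to compound 4 (0.08 log units; within the scatter) and a 2.0-fold higher number from compound 1 to compound 4 (0.29 log units; within the scatter) both stay within the scatter, which places compound 4 with the pentyl and pentan-3-yl esters and leaves compound 3 alone at the low end. Nothing shown gives a reason for this. Pentan-3-yl is also branched, so compound 1 goes against any reading that branching alone suffices. Going by these compounds, whether a 1-methylhexyl or 1-methyloctyl chain, or a chain ending in an amine, would stay with compound 3 remains open.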